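This account rests on a few compounds, and the source may have more. Where it says the series, first, only, none or still open, it means among the compounds named here.

Compounds measured so far:
compound 1 `COC(=O)C1=C(C)N=C(C)/C(=C(\O)OC)C1c1ccc(I)cc1` — 22900 nM
compound 2 `COC(=O)C1=C(C)N=C(C)/C(=C(\O)OC)C1c1ccccc1I` — 46.8 nM
compound 3 `COC(=O)C1=C(C)N=C(C)/C(=C(\O)OC)C1c1ccc(Br)cc1` — 540 nM

In a functional assay (muscle tissue) with Cavia porcellus as the target (on this read-out lower numbers stand for an effect already at smaller amounts and higher numbers for an effect only at larger amounts of compound), compound 3 stands second highest of the three numbers: its nearest neighbour is compound 2, with a 12-fold higher number from compound 2 to compound 3 (1.06 log units; beyond the scatter) separating them, and its furthest is compound 1, with a 42-fold lower number from compound 1 to compound 3 (1.63 log units; beyond the scatter) between them. Compound 4 `COC(=O)C1=C(C)N=C(C)/C(=C(\O)OC)C1c1cccc(Br)c1` has not yet been measured. It differs from compound 3 in one place: 3-bromophenyl in place of 4-bromophenyl on a saturated ring carbon.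

Going by the values given here, the steps that bear on this change are those in which the halogen moves around the phenyl ring. Going from the 4-iodophenyl compound to the 2-iodophenyl compound gave a 490-fold lower number from compound 1 to compound 2 (2.69 log units; beyond the scatter), and going back from 2-iodophenyl to 4-bromophenyl gave a 12-fold higher number from compound 2 to compound 3 (1.06 log units; beyond the scatter). Both show that where the halogen sits on the phenyl matters greatly in this assay, and that the 4-position is the weaker. Among the compounds with values here, no compound with a 3-substituted phenyl has been measured, so the size is uncertain, but a lower number is expected for compound 4, with a step of about a 4.5-fold lower number from compound 3 to compound 4 (0.65 log units; beyond the scatter). Compound 4 is therefore estimated at 120 nM, within 25 nM to 600 nM.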

Compound 4, half-maximal effective concentration: 1.29 nM
Estimate against measurement, compound 4: 93-fold (1.97 log units) above; measured number outside the range, below it.
By their numbers in this assay, from the lowest: compound 4; then compound 2; then compound 3; then compound 1.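

In this assay, 3-bromophenyl in place of 4-bromophenyl gives a 420-fold lower number from compound 3 to compound 4 (2.62 log units; beyond the scatter) with no change in the atoms present, so the place of the bromine on the phenyl ring alone carries a large effect. The earlier compounds shown here showed the 2-iodophenyl group ahead of both 4-halophenyl groups, but the 3-bromophenyl group goes further still, with a 36-fold lower number from compound 2 to compound 4 (1.56 log units; beyond the scatter) and an 18000-fold lower number from compound 1 to compound 4 (4.25 log units; beyond the scatter) making compound 4 the lowest of the four numbers. Nothing available explains why this change has so large an effect.

On these data alone, what a 3-iodophenyl or a 2-bromophenyl group would give remains open, so the roles of the halogen and its place cannot be separated in the steps that change both. Also open, as far as these compounds go, is how an amine or a carboxylic acid would fare on the phenyl ring in place of the bromine.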